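The compounds below may be only part of what the source reports. "The series", "measured", "known", "first", "only" and "open" are said of these compounds alone.

Measured so far in a functional assay on cells for positive allosteric modulation of metabotropic glutamate receptor 5 (Rattus norvegicus), read by calcium flux; on this read-out lower numbers stand for an effect already at smaller amounts and higher numbers for an effect only at larger amounts of compound:
- compound 1, `O=C(Nc1cc(-c2ccccc2)nn1-c1ccccc1)c1ccccc1`: 203 nM
- compound 2, `COc1cccc(C(=O)Nc2cc(-c3ccccc3)nn2-c2ccccc2)c1`: 102 nM
- compound 3, `O=C(Nc1cc(-c2ccccc2)nn1-c1ccccc1)c1cccc(C(F)(F)F)c1`: 228 nM

All three share the core of compound 1 and differ only in a single substituent on one six-membered aromatic ring of carbon only. Compound 1 sits close to both of the others: the step of a 1.1-fold higher number from compound 1 to compound 3 (0.05 log units; within the scatter) and the step of a 2.0-fold lower number from compound 1 to compound 2 (0.30 log units; within the scatter) are each within the scatter, so none of the three can be told apart from compound 1 with confidence. Among the compounds with values here, only the step of a 2.2-fold higher number from compound 2 to compound 3 (0.35 log units; beyond the scatter) reaches beyond the scatter, and it is modest.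

Compound 4, `O=C(Nc1cc(-c2ccccc2)nn1-c1ccccc1)c1ccc(OC(F)(F)F)cc1`, is the next member of the set. Its difference from compound 1 is trifluoromethoxy in place of hydrogen on an aromatic carbon. Within the data shown here, no measured step places a group at this position, so the two closest reference points are the steps from compound 1 to compound 2 and from compound 1 to compound 3, both small. A large move in this assay is therefore not expected; the likely outcome is a step of a 1.2-fold higher number from compound 1 to compound 4 (0.09 log units; within the scatter). Compound 4 is estimated at 250 nM in this assay, within a range from 90 nM to 700 nM.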

Compound 4, half-maximal effective concentration: 18 nM
Beside the measured number, compound 4's estimate is 14-fold (1.14 log units) above it; measured number outside the range, below it.
By their numbers in this assay, from the lowest: compound 4; then compounds 2, 1 and 3 (each within the scatter of the next, the first and the last beyond it).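

In this assay, the carbon para to a large group on the six-membered aromatic ring of carbon only proves to be a place where a single substitution can move the number a long way: trifluoromethoxy in place of hydrogen gives an 11-fold lower number from compound 1 to compound 4 (1.05 log units; beyond the scatter). This is the only large step among the compounds shown, whereas a 2.0-fold lower number from compound 1 to compound 2 (0.30 log units; within the scatter) and a 1.1-fold higher number from compound 1 to compound 3 (0.05 log units; within the scatter) both remain within the scatter, and neither of those changes puts a group at this position. The compounds shown thus reveal a sensitivity to substitution that the first three could not show, but no available data explain the size of this step.

With trifluoromethoxy as the only group shown at this position, it remains open whether the lower number follows from the position itself or depends on this particular group, a question that methoxy, trifluoromethyl, chlorine or an amine at the same carbon would help to settle. As far as these compounds go, it is also open whether trifluoromethoxy would produce a comparable step on another carbon of this ring, and whether a longer chain or a carboxylic acid would be accepted at this position.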